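Replacing 3-methylthiophen-2-yl in compound 1: working notes

A few compounds are considered here, and "the series" means these few. Any claim that something is new, unique, unknown or untested is made for them only; others in the source may bear on it.

Measured so far in a functional assay on DU-145 cells (Homo sapiens) for cytotoxicity, read by ELISA, with a stated time of 4 days; a lower number here means a stronger inhibitor, a higher number a weaker inhibitor:
- compound 1 `Cc1ccsc1-c1cc(-c2ccoc2)cc(-c2ccco2)n1` gives 30400 nM
- compound 2 `Cc1ccsc1-c1cc(-c2ccoc2)cc(-c2ccc(Cl)cc2)n1` gives 20100 nM

Compound 1 has a single measured neighbour, and the two numbers lie within the scatter of each other: a 1.5-fold lower number from compound 1 to compound 2 (0.18 log units; within the scatter). That step places 4-chlorophenyl in place of furan-2-yl on an aromatic carbon, so it concerns a different place from the change considered here.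

Compound 3 `Clc1ccc(-c2cc(-c3ccoc3)cc(-c3ccco3)n2)s1` has not yet been measured. It keeps the core of compound 1 and differs as follows: 5-chlorothiophen-2-yl in place of 3-methylthiophen-2-yl on an aromatic carbon. Going by the values given here, the new group, 5-chlorothiophen-2-yl, stands next to the ring nitrogen, and no measured step covers a change at that place. Among the compounds with values here, the one step available is small and elsewhere on the core, so it offers only loose guidance. On these data alone, on that basis, no shift beyond the scatter is expected in this assay, and the direction remains open. The expected change is a 1.5-fold lower number from compound 1 to compound 3 (0.18 log units; within the scatter). For compound 3 the estimated value is 20000 nM, with an expected range of 6000 nM to 50000 nM.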

Compound 3, half-maximal inhibitory concentration: 17200 nM
Compound 3: the middle estimate sits 1.2-fold (0.07 log units) above what was measured; the range from low to high includes it.
By their numbers in this assay, from the lowest: compounds 3, 2 and 1 (each within the scatter of the next).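

In this assay, the first step read at the place next to the ring nitrogen is a 1.8-fold lower number from compound 1 to compound 3 (0.25 log units; within the scatter). It exchanges 3-methylthiophen-2-yl for 5-chlorothiophen-2-yl, two groups that each have 6 heavy atoms and one five-membered aromatic ring with 1 hetero atom, so this particular exchange does not separate compound 1 from compound 3 in this assay. No information on the cause of this result is available for these compounds.

This step changes both the substituent on the five-membered ring and its location on that ring, and the compounds shown do not separate these two changes. On these data alone, it also remains open whether a group of a different kind at the place next to the ring nitrogen, such as an aminomethyl group, a carboxylic acid or a morpholine, would give a step beyond the scatter in this assay.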